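A sulfonyl for a benzyl on the ring nitrogen

This account rests on a few compounds, and the source may have more. Where it says the series, first, only, none or still open, it means among the compounds named here.

Compound 2 `COc1ccc(-c2cc(=O)c3c(OC)cc(OC)cc3n2Cc2ccccc2)cc1` was examined in a functional assay on HepG2 cells (Homo sapiens) for antiproliferative activity, with a stated time of 72 h; on this read-out higher numbers stand for an effect only at larger amounts of compound and lower numbers for an effect already at smaller amounts. Compound 2 reaches only the limit of the assay, > 17300 nM, so no number stands for it. Compound 3 `COc1ccc(-c2c(I)c(=O)c3c(OC)cc(OC)cc3n2S(=O)(=O)c2ccc(OC)cc2)cc1` likewise ends at a limit, > 17300 nM. For compound 1 `COc1ccc(-c2cc(=O)c3c(OC)cc(OC)cc3n2C)cc1` the outcome in this assay is "not determined" (no result reported). Two of the three entries thus rest on the same boundary (the limit of > 17300 nM in this assay, at which 2 of the 3 values shown sit). Compound 4 `COc1ccc(-c2cc(=O)c3c(OC)cc(OC)cc3n2S(=O)(=O)c2ccc(C=O)cc2)cc1` differs from compound 2 by (4-formylphenyl)sulfonyl in place of benzyl on an aromatic nitrogen. No measured pair among these compounds shows what such a change does, so in this assay the expected step is a step that the limit leaves unreadable from compound 2 to compound 4, none beyond the scatter, with compound 4 most likely again reported only as a limit. Compound 4 is therefore estimated at 20000 nM, with a range from 8000 nM to 50000 nM.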

Compound 4, half-maximal effective concentration: > 34400 nM
Compound 4 gave a limit, no number; the forecaster's own chance of this, stated with the estimate: 75%; at least 1.7-fold (0.23 log units) between middle value and limit.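

For the compounds shown here, compound 2 and compound 4 both end at limits rather than numbers, so no step between them can be read. The compounds shown leave open whether (4-formylphenyl)sulfonyl in place of benzyl on the aromatic nitrogen changes antiproliferative activity at all.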